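From Urea Link to Chlorinated Amide

The source may hold more compounds than are shown below. What is called first, only, known or untested is meant among the compounds shown, and "the series" means these compounds.

Compound 1, `COc1cc(-c2nn(-c3cccc(NC(=O)c4cccc(C(F)(F)F)c4)c3)cc2-c2ccncc2)ccc1Cl`: in a functional assay on KM12 cells (Homo sapiens) for inhibition, read by sulforhodamine B assay, with a stated time of 48 h (a lower number here means a stronger inhibitor of growth, a higher number a weaker inhibitor of growth), compound 1 gives 1660 nM.
Compound 2, `COc1cc(-c2nn(-c3cccc(NC(=O)Nc4cccc(C(F)(F)F)c4)c3)cc2-c2ccncc2)ccc1Cl`: in this assay compound 2 gives 573 nM.
Compound 3, `COc1cc(-c2nn(-c3cccc(NC(=O)c4ccc(Cl)c(C(F)(F)F)c4)c3)cc2-c2ccncc2)ccc1Cl`: not yet measured.

Among the measured compounds shown here, compound 2 has the lowest number of the two measured here; its only neighbour is compound 1, and the step of a 2.9-fold lower number from compound 1 to compound 2 (0.46 log units; beyond the scatter) lies beyond the usual scatter. Compound 3 differs from compound 2 in one place: 4-chloro-3-(trifluoromethyl)phenyl in place of (3-(trifluoromethyl)phenyl)amino on a carbonyl carbon. For the measured compounds named here, only one measured step bears on this change. Compound 1 and compound 2 differ by the same carbonyl-linked group being either an aryl or an arylamino, and that step was modest and beyond the scatter. Going by the values given here, compound 3 reverses that change, so a move back toward the number of compound 1 is expected, while the added chlorine has no measured counterpart here and widens the range. The expected step is a 2.1-fold higher number from compound 2 to compound 3 (0.32 log units; beyond the scatter). For compound 3 the estimate in this assay is 1200 nM, with a range from 400 nM to 3500 nM.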

Compound 3, concentration for 50% growth inhibition: 2060 nM
Beside the measured number, compound 3's estimate is 1.7-fold (0.23 log units) below it; low and high end bracket the measured number.
By their numbers in this assay, from the lowest: compound 2; then compounds 1 and 3 (each within the scatter of the next).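

Among the compounds shown here, the chlorine gives the first direct reading on the aromatic ring of the amide: in this assay, chloro in place of hydrogen yields a 1.2-fold higher number from compound 1 to compound 3 (0.09 log units; within the scatter), so the two amides cannot be told apart. Compound 3 therefore shows that this chlorine does not recover what the arylamino group on the carbonyl carbon provides, with a 3.6-fold higher number from compound 2 to compound 3 (0.56 log units; beyond the scatter), and compound 2 keeps the lowest number of the three, as both amides stand beyond the scatter from it. For this small set, the link on the carbonyl carbon matters more than the added chlorine, though no information here explains why the numbers fall as they do.

The compounds shown leave open whether the same chloro group would also make no readable difference on the urea of compound 2, where the arylamino group is still present. They also leave open whether an amine, a carboxylic acid or a longer chain in place of that chloro group would shift the number in this assay in either direction, on the amide or on the urea.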